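Ester Variation at the Side-Chain Carbonyl of the Shared Core

The source may report more compounds than this note shows. Statements on the series, on what has been measured and on what is new or still open speak of the compounds shown alone.

Compound 1 `O=C(O)CCCC(=O)OCCc1c(-c2ccccc2Cl)c2cc(Cl)ccc2[nH]c1=O` carries a 3-carboxypropyl group on the side-chain carbonyl carbon; in an ADME assay on HepG2 2.2.15 cells (Homo sapiens) for cytotoxicity (on this read-out lower numbers stand for higher toxicity in this test and higher numbers for lower toxicity in this test), compound 1 gives 110000 nM. Compound 2 `O=C(/C=C/c1cccc(F)c1)OCCc1c(-c2ccccc2Cl)c2cc(Cl)ccc2[nH]c1=O` carries 2-(3-fluorophenyl)ethenyl in that position. In this assay compound 2 reaches only a limit, > 1600000 nM, so no number is known for it. Going by the values given here, the one measured step is an at least 14-fold higher number from compound 1 to compound 2 (1.16 log units; beyond the scatter), and its size rests on (the limit of > 1600000 nM in this assay, at which 1 of the 2 values shown sits), so it is a lower bound rather than a settled difference.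

Compound 3 `C/C=C(\C)C(=O)OCCc1c(-c2ccccc2Cl)c2cc(Cl)ccc2[nH]c1=O` is not yet measured. It differs from compound 2 in 1-methylprop-1-en-1-yl in place of 2-(3-fluorophenyl)ethenyl on a carbonyl carbon. Among the compounds with values here, the only measured step bears on it indirectly: it shows that exchanging the ester acyl group can shift the read-out by a large amount, but compound 3 keeps an uncharged acyl group, so a return toward compound 1 is not indicated. A step within or near the scatter, possibly a modest fall, is expected.

Compound 3 is expected at 1000000 nM, with a range of 300000 nM to 3000000 nM. The expected step is an at least 1.6-fold lower number from compound 2 to compound 3 (0.20 log units; that floor lies within the scatter), likely ending at the limit again.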

Compound 3, half-maximal cytotoxic concentration: 350000 nM
For compound 3 the middle estimate is 2.9-fold (0.46 log units) above the measured one; the range from low to high includes it.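

Placing 1-methylprop-1-en-1-yl on the carbonyl carbon gives the first measured comparison in which the incoming group has no ring, and it separates this group from both neighbours in this assay: a 3.2-fold higher number from compound 1 to compound 3 (0.50 log units; beyond the scatter), and an at least 4.5-fold lower number from compound 2 to compound 3 (0.66 log units; beyond the scatter). The three compounds therefore fall into three distinct levels rather than two, with compound 1 lowest, compound 3 in the middle and compound 2 highest, so the read-out at this position does not depend only on whether the 3-carboxypropyl group is present. The second of these steps gives only a minimum size, since compound 2 holds a limit and not a number: the limit of > 1600000 nM in this assay, at which 1 of the 3 values shown sits.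

The exchange from compound 2 to compound 3 removes the fluorine, the aromatic ring and several heavy atoms at once, so the compounds shown do not separate the contributions of these features. From the compounds shown here alone, it remains open where a plain 2-phenylethenyl group without fluorine, or a chain ending in an amine, would fall relative to compound 2 and compound 3.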